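The source may hold more compounds than are shown below. What is called first, only, known or untested is meant among the compounds shown, and "the series" means these compounds.

Measured so far:
compound 1 `COc1ccc2oc(=O)c(/C=C/C(=O)N3CCC=CC3=O)c(O)c2c1`: 9800 nM
compound 2 `O=C1C=CCCN1C(=O)/C=C/c1c(O)c2ccc(F)cc2oc1=O`: 18000 nM

In a functional assay on A549 cells (Homo sapiens) for inhibition, read by MTT assay, with a stated time of 72 h (a lower number here means a stronger inhibitor, a higher number a weaker inhibitor), compound 2 gives 18000 nM, numerically the higher of the two numbers recorded. Compound 1 gives 9800 nM in this assay, and the gap between the two lies within the scatter, so no order of potency can be read from them. Compound 3 `O=C1C=CCCN1C(=O)/C=C/c1c(O)c2ccccc2oc1=O` has yet to be measured in this assay. It differs from compound 2 in one place: hydrogen in place of fluoro on an aromatic carbon. Among the measured compounds shown here, no step between measured compounds that differ in one place is available, so the size of this kind of change has no precedent. The replacement of fluoro by hydrogen is a small change to the core, and a step of no more than the usual scatter is expected, with no clear direction. Compound 3 is therefore estimated to give about 15000 nM in this assay, with a range from 6000 nM to 40000 nM. The expected step of a 1.2-fold lower number from compound 2 to compound 3 (0.08 log units; within the scatter) lies within the scatter of repeated measurements.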

Compound 3, half-maximal inhibitory concentration: 12000 nM
Estimate against measurement, compound 3: 1.3-fold (0.10 log units) above; measured number inside the range.
By their numbers in this assay, from the lowest: compounds 1, 3 and 2 (each within the scatter of the next).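

In this assay, the series now has its first steps between compounds that differ in one place, and both involve hydrogen on an aromatic carbon of the shared core. Hydrogen in place of fluoro gives a 1.5-fold lower number from compound 2 to compound 3 (0.18 log units; within the scatter), and hydrogen in place of methoxy gives a 1.2-fold higher number from compound 1 to compound 3 (0.09 log units; within the scatter), so neither fluoro nor methoxy can be told apart from hydrogen at the aromatic carbon it occupies, and the compound without either group does not stand apart from the other two. Nothing measured on hand speaks to the reason for these values, and the two steps describe only the size of each swap.

From the compounds shown here alone, whether any group on these aromatic carbons can move the number beyond the scatter remains open, since only fluoro, methoxy and hydrogen are compared, and an amine, a carboxylic acid or a longer chain such as butoxy could be set against them. The compounds shown also share the rest of the structure unchanged, so they say nothing about the ring hydroxyl or the unsaturated amide side chain, for instance with a methoxy in place of that hydroxyl.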